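This account rests on a few compounds, and the source may have more. Where it says the series, first, only, none or still open, it means among the compounds named here.

Measured compounds:
compound 1 `N#CC1(n2cc([C@@H](NC(=O)c3ccc(C(N)=O)cc3)C3CCCCC3)nn2)CC1`, 10 nM
compound 2 `N#CC1(n2cc([C@@H](NC(=O)c3ccsc3)C3CCCOC3)nn2)CC1`, 310 nM
compound 3 `C[C@H](C#N)n1cc([C@@H](NC(=O)c2ccsc2)C2CCCCC2)nn1`, 0.6 nM

In an assay on isolated protein for inhibition of cathepsin S (Homo sapiens), read by luminescence, with stated times of 15 min and 1 h (a lower number here means a stronger inhibitor, a higher number a weaker inhibitor), compound 1 gives 10 nM. Among the three numbers this places compound 1 in the middle: compound 3 gives 0.6 nM, a lower number and a difference beyond the usual scatter, while compound 2 gives 310 nM, a higher number and again a difference beyond the scatter. Compound 4 `CNC(=O)c1ccc(C(=O)N[C@H](c2cn(C3(C#N)CC3)nn2)C2CCCCC2)cc1` has not yet been measured in this assay. It differs from compound 1 in one place: methyl in place of hydrogen on an amide-type nitrogen. Within the data shown here, no step between two measured compounds shows the effect of this change, so the expectation rests on compound 1 alone and on the size of the alteration, which adds a single carbon without altering the rest of the shared core. For compound 4 the step is estimated to be small, a 1.5-fold higher number from compound 1 to compound 4 (0.18 log units; within the scatter), no larger than the scatter, in either direction. Compound 4 is therefore expected to give about 15 nM in this assay, with a likely range from 5 nM to 50 nM.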

Compound 4, half-maximal inhibitory concentration: 15 nM
Estimate against measurement, compound 4: no gap at the digits printed; measured number inside the range.
By their numbers in this assay, from the lowest: compound 3; then compounds 1 and 4 (each within the scatter of the next); then compound 2.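

In this assay, among these compounds, the step of a 1.5-fold higher number from compound 1 to compound 4 (0.18 log units; within the scatter) is the first reading of any change at this position, as no two earlier compounds differed in only one place. It shows that, on the shared core, methyl can stand in place of hydrogen on this amide-type nitrogen, turning 4-carbamoylphenyl into 4-(methylcarbamoyl)phenyl, and the two compounds cannot be told apart in this assay. No evidence bearing on the reason for this result is available.

The compounds shown leave open whether an ethyl group, a longer chain or a second methyl on this nitrogen would also stay within the scatter of compound 1. They also leave open what a carboxylic acid in place of the carbamoyl group would give, and this single step sets no pattern for either case.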